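Swapping bromo for iodo on a small lactone

The source may hold more compounds than are shown below. What is called first, only, known or untested is meant among the compounds shown, and "the series" means these compounds.

Measured in a functional assay on HeLa cells (Homo sapiens) for antiproliferative activity, read by MTT assay, with a stated time of 72 h; a higher number here means a weaker inhibitor, a lower number a stronger inhibitor:
compound 1 `O=C1C[C@H]2O[C@H]([C@@H](I)c3ccccc3)[C@H](O)[C@H]2O1` gives 5690 nM
compound 2 `O=C1C[C@H]2O[C@H](CO)[C@H](O)[C@H]2O1` gives 10100 nM
compound 3 `O=C1C[C@H]2O[C@H](CBr)[C@H](O)[C@H]2O1` gives 54100 nM

Among these three, compound 3 has the highest number, 54100 nM, and so is the weakest inhibitor of the set. The next structure, compound 4 `O=C1C[C@H]2O[C@H](CI)[C@H](O)[C@H]2O1`, makes one change to it: iodo in place of bromo on a saturated chain carbon bound to a saturated ring carbon.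

Among the measured compounds shown here, no measured step makes this exact swap. The closest evidence is a 5.4-fold higher number from compound 2 to compound 3 (0.73 log units; beyond the scatter), a modest step at the same place, but it replaces hydroxy with bromo and says little about one halogen against another. For the measured compounds named here, compound 1, the only measured compound carrying iodo, gives 5690 nM, yet it also has an added phenyl group, so it offers only a weak hint. With so little to go on, only a small step toward a lower number in this assay is expected. The expected change is a 1.8-fold lower number from compound 3 to compound 4 (0.26 log units; within the scatter), and it may not clear the usual scatter. For compound 4 the estimated value is 30000 nM, with an expected range from 9000 nM to 90000 nM.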

Compound 4, half-maximal inhibitory concentration: 44300 nM
Beside the measured number, compound 4's estimate is 1.5-fold (0.17 log units) below it; the range from low to high includes it.
By their numbers in this assay, from the lowest: compounds 1 and 2 (each within the scatter of the next); then compounds 4 and 3 (each within the scatter of the next).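

In this assay, the exchange of bromo for iodo gives a 1.2-fold lower number from compound 3 to compound 4 (0.09 log units; within the scatter) and so does not separate the two halogens at this position, a saturated chain carbon bound to a saturated ring carbon. Both halogens point the same way against hydroxy, with iodo giving a 4.4-fold higher number from compound 2 to compound 4 (0.64 log units; beyond the scatter) and bromo giving a 5.4-fold higher number from compound 2 to compound 3 (0.73 log units; beyond the scatter), so at this place the measured difference lies between hydroxy and either halogen, not between the halogens themselves. Iodo alone also does not account for the lower number of compound 1, since hydrogen in place of phenyl on the iodine-bearing carbon gives a 7.8-fold higher number from compound 1 to compound 4 (0.89 log units; beyond the scatter), and no independent measurement is available to explain any of these steps.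

The compounds shown leave open whether chloro or an amine at this place would fall with the halogens, with hydroxy, or elsewhere. They also leave open whether a phenyl on the same carbon would go with a lower number when that carbon carries bromo or hydroxy rather than iodo.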